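The source may hold more compounds than are shown below. What is called first, only, known or untested is meant among the compounds shown, and "the series" means these compounds.

Working notes on the series.

The shared core is seen in compound 1 `CC1=C(/C=C/C(=O)/C=C/c2ccc(F)cc2)C(C)(C)CCC1`; its partners differ only in the substituent carried by the aromatic ring at the end of the chain. In a functional assay on PC-3 cells (Homo sapiens) for cytotoxicity, read by sulforhodamine B assay, with a stated time of 48 h (a lower number here means a stronger inhibitor, a higher number a weaker inhibitor), compound 1 gives 8200 nM, the second highest of the three numbers measured. Compound 2 `COc1ccc(/C=C/C(=O)/C=C/C2=C(C)CCCC2(C)C)cc1` gives 58700 nM, and compound 3 `CC1=C(/C=C/C(=O)/C=C/c2ccc([N+](=O)[O-])cc2)C(C)(C)CCC1` gives 1900 nM. The step of a 7.2-fold higher number from compound 1 to compound 2 (0.85 log units; beyond the scatter) and the step of a 4.3-fold lower number from compound 1 to compound 3 (0.64 log units; beyond the scatter) show that an exchange at this ring can move the number in either direction; the step of a 31-fold lower number from compound 2 to compound 3 (1.49 log units; beyond the scatter) is the largest gap in the set.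

Compound 4 `CC1=C(/C=C/C(=O)/C=C/c2ccccc2C)C(C)(C)CCC1` is the next step from compound 1: 2-methylphenyl in place of 4-fluorophenyl on a double-bonded chain carbon bound to a double-bonded chain carbon. For the measured compounds named here, no measured step involves a methyl group or a 2-methylphenyl, so none bears directly on this change; the steps from compound 1 to compound 2 and from compound 1 to compound 3 only show the size that a change at this ring has reached so far, modest in both directions. Going by the values given here, with no direct precedent, for compound 4 the step of a 1.2-fold higher number from compound 1 to compound 4 (0.09 log units; within the scatter) is expected to stay within the scatter. Compound 4 is therefore estimated at 10000 nM, with a range from 3000 nM to 35000 nM.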

Compound 4, half-maximal inhibitory concentration: 44100 nM
Beside the measured number, compound 4's estimate is 4.4-fold (0.64 log units) below it; the measured number lies above the stated range.
By their numbers in this assay, from the lowest: compound 3; then compound 1; then compounds 4 and 2 (each within the scatter of the next).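

In this assay, the exchange of 4-fluorophenyl for 2-methylphenyl on a double-bonded chain carbon bound to a double-bonded chain carbon is not a neutral one (a 5.4-fold higher number from compound 1 to compound 4 (0.73 log units; beyond the scatter)), although both groups count the same number of heavy atoms, neither carries a hydrogen-bond donor or acceptor, and neither has a net charge, so these counts alone do not hold the number in place. Together with the methoxy exchange (a 7.2-fold higher number from compound 1 to compound 2 (0.85 log units; beyond the scatter)), this gives two changes at this ring that raise the number from compound 1, while compound 3 goes against that direction (a 4.3-fold lower number from compound 1 to compound 3 (0.64 log units; beyond the scatter)). No supporting measurement bears on why this exchange moves the number.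

The step from compound 1 to compound 4 replaces the fluoro group with a methyl group and also changes the substituted ring position named by the two groups, so the compounds shown cannot separate those two parts of the exchange. Also open, going by these compounds, is how an unsubstituted phenyl or a ring bearing an amine would stand against compound 1 at this place.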